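The compounds below may be only part of what the source reports. "The series", "measured", "known", "first", "only" and "open" are said of these compounds alone.

In a functional assay on HepG2 cells (Homo sapiens) for antiproliferative activity, read by MTT assay, with a stated time of 48 h (a higher number here means a weaker inhibitor, a lower number a stronger inhibitor), two compounds built on a shared core have been measured so far. Compound 1 (`CC(=O)N1N=C(c2ccc3ccccc3c2)OC1c1ccc(Cl)cc1`) gives 1.88 ug/mL, the higher of the two numbers, which makes it the weaker inhibitor of the pair. Compound 2 (`CC(=O)N1N=C(c2ccc3ccccc3c2)OC1c1ccc2ccccc2c1`) gives 0.85 ug/mL, and this gap lies beyond the usual scatter. Compound 3 (`CC(=O)N1N=C(c2ccc3ccccc3c2)OC1c1ccccn1`) has not yet been measured. It carries pyridin-2-yl in place of 4-chlorophenyl on a saturated ring carbon, a position next to the ring nitrogen and next to the ring oxygen: pyridin-2-yl in place of 4-chlorophenyl on a saturated ring carbon. Within the data shown here, no measured pair differing in one place is available as a guide, so the expectation rests on little. Compound 1 stands at 1.88 ug/mL, and the exchange keeps a six-membered aromatic ring at the same carbon, so no step beyond the scatter is expected in this assay, and neither direction is favoured with any confidence. The step expected is a 1.2-fold higher number from compound 1 to compound 3 (0.07 log units; within the scatter). Compound 3 is estimated at 2.2 ug/mL, with an expected range from 0.8 ug/mL to 6 ug/mL.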

Compound 3, half-maximal inhibitory concentration: 5.26 ug/mL
The estimate for compound 3 lay 2.4-fold (0.38 log units) below the measured number, and the stated range covers the measured number.
By their numbers in this assay, from the lowest: compound 2; then compound 1; then compound 3.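

At the saturated ring carbon of the shared core, six-membered aromatic rings are not interchangeable in this assay: pyridin-2-yl in place of 4-chlorophenyl gives a 2.8-fold higher number from compound 1 to compound 3 (0.45 log units; beyond the scatter) and this modest step lies beyond the usual scatter. Before this result, the position had been seen only with the groups of compound 1 at 1.88 ug/mL and compound 2 at 0.85 ug/mL and neither carries a hetero atom in the ring at this carbon, whereas compound 3 does and has the highest number of the three. No measured information on the properties of these groups bears on this step, so the data give its size and direction and nothing about its origin.

The change removes the chlorine and brings in the ring nitrogen in a single step, so the compounds shown cannot assign the step to either alteration alone. An unsubstituted phenyl ring at this carbon would separate those two alterations, while pyridin-3-yl or pyridin-4-yl would show whether the place of the ring nitrogen matters.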